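The compounds below may be only part of what the source reports. "The series", "measured", "known", "first", "only" and "open" are said of these compounds alone.

Series notes. Three measured compounds share one core and differ only in the aryl group on the five-membered ring carbon that sits next to the ring atom bearing the carboxy group. In a functional assay on BJAB cells (Homo sapiens) for antiproliferative activity, with a stated time of 4 days (a lower number here means that less compound is needed, a higher number that more compound is needed for the effect), compound 3 `Cc1cc(-c2c(C)nn(-c3nc(-c4ccc(Cl)c(Cl)c4)c(SC(C)C)s3)c2C(=O)O)cc(C)n1` gives 580 nM, the lowest number of the three. Compound 1 `Cc1nn(-c2nc(-c3ccc(Cl)c(Cl)c3)c(SC(C)C)s2)c(C(=O)O)c1-c1cccc(F)c1` gives 900 nM in this assay, and compound 2 `Cc1nn(-c2nc(-c3ccc(Cl)c(Cl)c3)c(SC(C)C)s2)c(C(=O)O)c1-c1cnn(C)c1` gives 6800 nM. The steps: a 1.6-fold lower number from compound 1 to compound 3 (0.19 log units; within the scatter); a 7.6-fold higher number from compound 1 to compound 2 (0.88 log units; beyond the scatter); a 12-fold lower number from compound 2 to compound 3 (1.07 log units; beyond the scatter). So the pyridinyl and the fluorophenyl sit together within the scatter, while the methylpyrazolyl stands apart.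

Compound 4 `CNc1cc(-c2c(C)nn(-c3nc(-c4ccc(Cl)c(Cl)c4)c(SC(C)C)s3)c2C(=O)O)ccn1` differs from compound 3 by 2-(methylamino)pyridin-4-yl in place of 2,6-dimethylpyridin-4-yl on an aromatic carbon. The six-membered ring with one ring nitrogen is kept; only the ring substituents change. Among the compounds with values here, the step from compound 1 to compound 3 bears on this most directly and lay within the scatter, whereas the one larger step involved a change of ring type, which is not the case here. The step of a 1.7-fold higher number from compound 3 to compound 4 (0.24 log units; within the scatter) is therefore expected to stay small, with a slight lean toward a higher number. For compound 4 in this assay the estimate is 1000 nM, with a range from 350 nM to 3000 nM.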

Compound 4, half-maximal effective concentration: 18000 nM
Estimate against measurement, compound 4: 18-fold (1.26 log units) below; the whole stated range lies below it.
By their numbers in this assay, from the lowest: compounds 3 and 1 (each within the scatter of the next); then compound 2; then compound 4.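

In this assay, keeping the six-membered aromatic ring with 1 hetero atom does not keep the number in place: changing only its substituents gives a 31-fold higher number from compound 3 to compound 4 (1.49 log units; beyond the scatter) and this is the largest step in the set, so a large step here does not need a change of ring type. The same group gives a 20-fold higher number from compound 1 to compound 4 (1.30 log units; beyond the scatter) and also a 2.6-fold higher number from compound 2 to compound 4 (0.42 log units; beyond the scatter) so that the methylpyrazolyl group no longer marks the high end of the series. The entering group carries 1 hydrogen-bond donor where the leaving group carries 0, but no available data explain the step.

Going by these compounds, whether the step follows the amine hydrogen of the methylamino group stays open, and a dimethylamino group in its place would bear on that. Also open, on these data alone, is what the two methyl groups of 2,6-dimethylpyridin-4-yl contribute, which the plain pyridin-4-yl group would address.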